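The compounds below may be only part of what the source reports. "The series", "measured", "known", "first", "only" and "open" are said of these compounds alone.

Compounds measured in an assay on isolated protein for inhibition of cytosolic endo-beta-N-acetylglucosaminidase (Homo sapiens), tested at 1000 uM; a lower number here means less inhibition, a higher number more inhibition at the concentration tested (going by the name of the read-out):

- compound 1, `O=C(O)[C@H]1NC[C@H](O)[C@H](O)[C@H]1O`: 7.6%
- compound 2, `O=C(O)[C@@H]1NC[C@@H](O)[C@@H](O)[C@H]1O`: 26%
- compound 3, `O=C(O)[C@H]1NC[C@@H](O)[C@@H](O)[C@@H]1O`: 28%

Among the three measured compounds, compound 1 stands lowest in this assay; its nearest neighbour is compound 2, and compound 3 lies furthest from it, both of them above it beyond the scatter. The three compounds share the same atoms and bonds and differ only in configuration. The step of a number 18.4 percentage points higher from compound 1 to compound 2 (beyond the scatter) and the step of a number 20.4 percentage points higher from compound 1 to compound 3 (beyond the scatter) each went with an inversion at three of the four stereocentres, as noted in the fact that compounds 1 and 2 differ only in the configuration as drawn and (the fact that compounds 1 and 3 differ only in the configuration as drawn). Between compound 2 and compound 3 the step of a number 2 percentage points higher from compound 2 to compound 3 (within the scatter) stayed within the scatter, although two stereocentres differ there, as noted in the fact that compounds 2 and 3 differ only in the configuration as drawn.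

Compound 4, `O=C(O)[C@@H]1NC[C@@H](O)[C@H](O)[C@H]1O`, has not yet been measured in this assay. It is related to compound 1 as follows: the two compounds have the same atoms and bonds and differ only in configuration as drawn: 2 of 4 stereo elements differ; a stereocentre at a saturated ring carbon is drawn S in compound 1 and R in compound 4; a stereocentre at a saturated ring carbon is drawn S in compound 1 and R in compound 4. The two steps that bear on this change, from compound 1 to compound 2 and from compound 1 to compound 3, were both modest rises beyond the scatter, whereas the change within the upper pair was flat. On that basis a modest rise is expected for compound 4, of roughly the size a number 12.4 percentage points higher from compound 1 to compound 4 (beyond the scatter). Compound 4 is therefore estimated at 20% in this assay, within a range from 5% to 38%.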

Compound 4, a percentage reported as inhibition, at one concentration (the size of the read-out at that concentration, not a potency): 50%
Compound 4: the middle estimate sits 30 percentage points below what was measured; measured number above the stated range.
By their numbers in this assay, from the lowest: compound 1; then compounds 2 and 3 (each within the scatter of the next); then compound 4.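

In this assay, a single stereocentre turns out to matter on its own: the one pair here that differs at only one centre, drawn R on one side and S on the other, gives a number 24 percentage points higher from compound 2 to compound 4 (beyond the scatter): the fact that compounds 2 and 4 differ only in the configuration as drawn Inverting two centres gives a number 42.4 percentage points higher from compound 1 to compound 4 (beyond the scatter), which is more than either earlier step involving three inversions, so the count of inverted centres does not set the size of the change among these compounds: the fact that compounds 1 and 4 differ only in the configuration as drawn A further three-centre change gives a number 22 percentage points higher from compound 3 to compound 4 (beyond the scatter), which shows that the flat pair of compound 2 and compound 3 did not mark an upper level for this set of configurations: the fact that compounds 3 and 4 differ only in the configuration as drawn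

On these data alone, all four compounds keep the carboxylic acid, the amine and the hydroxyl groups, so it remains open whether the configuration of compound 4 would hold its reading with a methyl ester or an amide in place of the carboxylic acid, or with a longer chain on the amine. Each number is also a reading at a single concentration, so it gives no potency for any of these compounds.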